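Formyl to methyl on a weakly cytotoxic series

The source may hold more compounds than are shown below. What is called first, only, known or untested is meant among the compounds shown, and "the series" means these compounds.

In a functional assay on A549 cells (Homo sapiens) for cytotoxicity, read by MTT assay (on this read-out higher numbers stand for weaker inhibition and lower numbers for stronger inhibition), compound 1 `COc1cc(O)c(C=O)c2c1[C@H](O)C[C@@H](c1ccccc1)O2` gives 147000 nM. Compound 2 `COc1c(C)c(OC)c2c(c1C=O)O[C@H](c1ccccc1)C[C@H]2O` gives 137000 nM, which lies within the scatter of compound 1, so the two cannot be ranked. Going by the values given here, both formyl-bearing compounds therefore sit at the same level on the numbers so far.

Compound 3 `COc1c(C)c(OC)c2c(c1C)O[C@H](c1ccccc1)C[C@H]2O` differs from compound 2 by having methyl in place of formyl on an aromatic carbon. Among the compounds with values here, no measured pair isolates this change, so the expectation has only one close anchor. With compound 2 at 137000 nM as that anchor, no step beyond the scatter is expected in this assay, and neither direction is favoured. The estimated change is a 1.1-fold higher number from compound 2 to compound 3 (0.04 log units; within the scatter). For compound 3 the expected value is 150000 nM, with an estimated range of 70000 nM to 320000 nM.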

Compound 3, half-maximal inhibitory concentration: "not active" (no number reported)
Nothing numeric was reported for compound 3, so the estimate cannot be set against anything.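

Going by these compounds alone, compound 3 is reported as "not active" in this assay with no number, so no step from compound 2 to compound 3 can be read. The compounds shown leave open how methyl in place of formyl shifts the read-out. No evidence on hand bears on this result.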